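The source may hold more compounds than are shown below. What is called first, only, known or untested is meant among the compounds shown, and "the series" means these compounds.

In a functional assay on MCF7 cells (Homo sapiens) for cytotoxicity, read by CellTiter-Glo, with a stated time of 5 days (on this read-out lower numbers stand for stronger inhibition and higher numbers for weaker inhibition), compound 1 `CC/C(=C(/c1ccc(/C=C/C(=O)O)cc1)c1ccc2[nH]nc(C)c2c1)c1ccccc1` reaches only a limit, > 1000 nM. Compound 2 `CC/C(=C(/c1ccc(/C=C/C(=O)O)cc1)c1ccc2[nH]ncc2c1C)c1ccccc1`, by contrast, gives 50 nM in this assay. For the measured compounds named here, the one measured step between them is an at least 20-fold lower number from compound 1 to compound 2 (1.30 log units; beyond the scatter). Going by the values given here, compound 2 thus stands as the holder of the only genuine number in this assay; the other value, (the limit of > 1000 nM in this assay, at which 1 of the 2 values shown sits), is a limit of the assay and not a number, so the step from compound 1 can be read only as a lower bound.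

Compound 3 `CC/C(=C(/c1ccc(/C=C/C(=O)O)cc1)c1ccc2[nH]ncc2c1C#N)c1ccccc1` carries cyano in place of methyl on an aromatic carbon. Among the compounds with values here, no measured step exchanges a methyl for a cyano, and the only step in hand moved a methyl from one place on the group to another; that step was large, which shows that the group on the double-bonded chain carbon matters greatly to the read-out, but it gives no direction for a cyano in the place of the methyl that compound 2 already holds. The expected step is therefore modest and uncertain, a 1.8-fold higher number from compound 2 to compound 3 (0.26 log units; within the scatter). Compound 3 is estimated at 90 nM, within a range from 25 nM to 350 nM.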

Compound 3, half-maximal inhibitory concentration: 1.5 nM
The estimate for compound 3 lay 60-fold (1.78 log units) above the measured number; the measured number lies below the stated range.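

Exchanging methyl for cyano on this aromatic carbon, ortho to a fused ring and ortho to a large group, gives a second large change in this assay (a 33-fold lower number from compound 2 to compound 3 (1.52 log units; beyond the scatter)). The earlier step showed that the place of the methyl on the group matters; this one shows that, with the place held fixed, the identity of the group on this single aromatic carbon also moves the number well beyond the scatter, so the methyl of compound 2 was not the limit of what this place can give. The exchange adds one heavy atom, a triple bond and a hydrogen-bond acceptor, but nothing shown ties the change in the number to any one of these, and no measured property among the data bears on its cause.

The compounds shown leave open whether an ethynyl group, which keeps the triple bond but has no nitrogen, or a chlorine atom in this place would give a number like that of compound 3. They also leave open how a carboxamide, or a longer chain ending in a nitrile, would behave on this same carbon.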